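The source may hold more compounds than are shown below. What is called first, only, known or untested is meant among the compounds shown, and "the series" means these compounds.

Compound 3, `N=C(NCCCc1c[nH]cn1)NCCC(c1ccncc1)c1ccc(F)cc1`, is one of three related guanidines tested in a functional assay on ileum for antagonist activity at histamine H1 receptor (Cavia porcellus); on this read-out higher numbers stand for weaker binding and lower numbers for tighter binding. In this assay compound 3 gives 37.2 nM. The closest of the other two is compound 2, `N=C(NCCCc1c[nH]cn1)NCCC(c1ccc(F)cc1)c1ccccn1`, which in this assay gives 22.4 nM; the single-point change that turns compound 2 into compound 3 produces a 1.7-fold higher number from compound 2 to compound 3 (0.22 log units; within the scatter). The third, compound 1, `COc1ccc(C(CC/N=C(\N)NCCCc2c[nH]cn2)c2ccccn2)cc1`, gives 269 nM in this assay, and it differs from both others in more than one place, so no single step can be read from it.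

Compound 4, `N=C(NCCCc1c[nH]cn1)NCCC(Cc1ccccc1)c1ccc(F)cc1`, is not yet measured. It differs from compound 3 by benzyl in place of pyridin-4-yl on a saturated chain carbon bound to an aromatic carbon and a saturated chain carbon. Going by the values given here, no measured step swaps an aromatic ring with a nitrogen for a ring of carbon only at this position; the only measured step at this position is the one from compound 2 to compound 3, which merely moves the nitrogen within the ring and stays within the scatter. For compound 4 the expected result is therefore uncertain, with a 1.6-fold higher number from compound 3 to compound 4 (0.21 log units; within the scatter) as the estimated step. The estimate for compound 4 in this assay is 60 nM, within a range of 15 nM to 250 nM.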

Compound 4, dissociation constant: 141 nM
Compound 4: middle estimate off by 2.4-fold (0.37 log units), on the low side; the range from low to high includes it.
By their numbers in this assay, from the lowest: compounds 2 and 3 (each within the scatter of the next); then compounds 4 and 1 (each within the scatter of the next).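

The earlier step at this position only moved the nitrogen within the ring and stayed within the scatter, so it gave no sign that the position responds to what it carries. Replacing the pyridine ring with benzyl does register in this assay: pyridin-4-yl to benzyl gives a 3.8-fold higher number from compound 3 to compound 4 (0.58 log units; beyond the scatter), and pyridin-2-yl to benzyl gives a 6.3-fold higher number from compound 2 to compound 4 (0.80 log units; beyond the scatter), so among these compounds the group on this saturated chain carbon does matter. Nothing measured here explains the rise in the number.

Benzyl removes the ring nitrogen and adds a chain carbon in one change, and the compounds shown do not separate the two. A plain phenyl group on the same carbon would test the nitrogen alone, and a pyridinylmethyl group would test the added carbon alone.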